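Bromo in place of propyl on a weak compound

The compounds below may be only part of what the source reports. "The series", "measured", "known", "first", "only" and "open" are said of these compounds alone.

In a functional assay for inhibition, with Rattus norvegicus as the target (a lower number here means a stronger inhibitor, a higher number a weaker inhibitor), compound 1 (`CC(C)(C)/N=c1\c(O)c(O)\c1=N/c1cccnc1`) gives 2800 nM and compound 2 (`CC(C)(C)/N=c1\c(O)c(O)\c1=N/c1ccc(C#N)cc1`) gives 560 nM as measured values. Compound 3 (`CCCc1cc(C#N)ccc1/N=c1\c(O)c(O)\c1=N/[C@H](C)C(C)(C)C`) gives 23100 nM as the highest of the three numbers, beyond the scatter from both of the others.

The next compound to be measured is compound 4 (`C[C@@H](/N=c1\c(O)c(O)\c1=N/c1ccc(C#N)cc1Br)C(C)(C)C`). It carries bromo in place of propyl on an aromatic carbon, ortho to a large group and meta to a cyano group, and the rest of compound 3 stays as it is. Among the compounds with values here, no measured pair isolates this change, so the evidence is indirect. Compound 2, which has no propyl group, gives 560 nM as the closest guide, but it also carries a different alkyl group on the shared core. The estimated move is a 9.2-fold lower number from compound 3 to compound 4 (0.97 log units; beyond the scatter) toward a lower number in this assay, beyond the scatter. For compound 4 the expected value is 2500 nM with an estimated range from 400 nM to 12000 nM in this measurement.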

Compound 4, half-maximal inhibitory concentration: 75 nM
Estimate against measurement, compound 4: 33-fold (1.52 log units) above; the measured number lies below the stated range.
By their numbers in this assay, from the lowest: compound 4; then compound 2; then compound 1; then compound 3.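

In this assay, within the data shown here, bromo in place of propyl gives a 310-fold lower number from compound 3 to compound 4 (2.49 log units; beyond the scatter), the only direct reading so far on this aromatic carbon, ortho to a large group and meta to a cyano group. With the rest of compound 3 unchanged, the number depends strongly on the group at this position, which compound 1 and compound 2 could not show, as each differs from compound 3 in more than one place. Nothing available accounts for the size of this step.

On these data alone, with only propyl and bromo read here, it remains open whether chloro, methyl or methoxy at this position would track bromo or propyl. Also open, as far as these compounds go, is whether adding bromo to compound 2, which carries a different alkyl group on the shared core, would lower its number.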